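The compounds below may be only part of what the source reports. "The series", "measured", "known", "first", "only" and "open" are said of these compounds alone.

Measured so far in an ADME assay on cells (Rhabdomyosarcoma cell, Homo sapiens) for cytotoxicity, read by MTT assay, with a stated time of 72 h; a lower number here means that less compound is tolerated, a higher number that more compound is tolerated:
Compound 1 `Clc1ccc(/C=N/c2sc3c(c2-c2nc4ccccc4s2)CCCC3)c(Cl)c1` gives 56.6 ug/mL.
Compound 2 `O=[N+]([O-])c1ccc(/C=N/c2sc3c(c2-c2nc4ccccc4s2)CCCC3)cc1` gives 316 ug/mL.

Compound 2 holds the highest of the two numbers in this assay; its nearest neighbour is compound 1, and the move between them was a 5.6-fold higher number from compound 1 to compound 2 (0.75 log units; beyond the scatter). Compound 3 `Oc1ccccc1/C=N/c1sc2c(c1-c1nc3ccccc3s1)CCCC2` has not been measured yet. It differs from compound 2 in one place: 2-hydroxyphenyl in place of 4-nitrophenyl on a carbon with a double bond to nitrogen. Among the compounds with values here, the only measured step that bears on this change is the one from compound 1 to compound 2, where swapping the group on that same carbon moved the number by a modest amount. Within the data shown here, no measured pair shows what a 2-hydroxyphenyl does here, so the direction rests on weak ground. A step of about the same modest size, or none beyond the scatter, is expected; the estimated step is a 2.1-fold lower number from compound 2 to compound 3 (0.32 log units; beyond the scatter). Compound 3 is therefore estimated at 150 ug/mL, with a range from 50 ug/mL to 400 ug/mL.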

Compound 3, half-maximal cytotoxic concentration: 42.4 ug/mL
Compound 3: middle estimate off by 3.5-fold (0.55 log units), on the high side; the measured number lies below the stated range.
By their numbers in this assay, from the lowest: compounds 3 and 1 (each within the scatter of the next); then compound 2.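

In this assay, the group on the carbon with a double bond to nitrogen can matter in both directions: 2-hydroxyphenyl in place of 4-nitrophenyl gives a 7.5-fold lower number from compound 2 to compound 3 (0.87 log units; beyond the scatter). By contrast, 2-hydroxyphenyl in place of 2,4-dichlorophenyl gives a 1.3-fold lower number from compound 1 to compound 3 (0.13 log units; within the scatter), so these two groups cannot be told apart here, and among the three compounds only the 4-nitrophenyl of compound 2 stands out. Nothing measured on these compounds offers an explanation for this difference.

Whether the high number of compound 2 depends on the nitro group stays open, as the other two compounds shown do not carry one. Also open, from the compounds shown here alone, is how an amine, a carboxylic acid or a longer chain at this place would read in this assay.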